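This account rests on a few compounds, and the source may have more. Where it says the series, first, only, none or still open, it means among the compounds named here.

Compound 1 `C=C(Br)C(=O)Nc1cccc(-c2cn3nc(Cc4ccc(OC)cc4)sc3n2)c1` gives 1400 nM in a functional assay on L1210 cells (Mus musculus) for inhibition, read by cell counting, with a stated time of 2 days (a lower number here means a stronger inhibitor, a higher number a weaker inhibitor), the highest of the three numbers at hand: compound 2 `C=C(Br)C(=O)Nc1cccc(-c2cn3nc(-c4cccc(OC)c4)sc3n2)c1` gives 580 nM and compound 3 `C=C(Br)C(=O)Nc1cccc(-c2cn3nc(-c4ccc(OC)cc4)sc3n2)c1` gives 940 nM. The step of a 2.4-fold lower number from compound 1 to compound 2 (0.38 log units; beyond the scatter) lies beyond the scatter, while a 1.5-fold lower number from compound 1 to compound 3 (0.17 log units; within the scatter) and a 1.6-fold higher number from compound 2 to compound 3 (0.21 log units; within the scatter) stay within it. Compound 4 `COc1ccc(Cc2nn3cc(-c4cccc(N)c4)nc3s2)cc1` differs from compound 1 at the other end of the molecule: hydrogen in place of (1-bromoethenyl)carbonyl on a nitrogen on an aromatic ring. Within the data shown here, none of the measured steps touches this part of compound 1, so no measured step bears on the change, and the expectation rests on the structural difference alone. Compound 4 is therefore expected to give a higher number than compound 1, with wide uncertainty, estimated at 8000 nM within a range from 1500 nM to 40000 nM, a step of a 5.7-fold higher number from compound 1 to compound 4 (0.76 log units; beyond the scatter).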

Compound 4, half-maximal inhibitory concentration: 227000 nM
Estimate against measurement, compound 4: 28-fold (1.45 log units) below, and the stated range ends below it.
By their numbers in this assay, from the lowest: compounds 2, 3 and 1 (each within the scatter of the next, the first and the last beyond it); then compound 4.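

In this assay, the change from ((1-bromoethenyl)carbonyl)amino to amino gives a 160-fold higher number from compound 1 to compound 4 (2.21 log units; beyond the scatter), a far larger step than any seen at the other end of the molecule, where the largest is a 2.4-fold lower number from compound 1 to compound 2 (0.38 log units; beyond the scatter). Among these compounds, the (1-bromoethenyl)carbonyl on this nitrogen therefore matters much more to the number in this assay than the differences among the earlier compounds. Nothing available bears on the reason for this step.

The compounds shown do not separate the contribution of the bromine from that of the rest of the group. An acetyl or a plain propenoyl on the same nitrogen would tell them apart.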